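Pyrrolidin-1-yl for 4-Methylpiperazin-1-yl on the Thiocarbonyl Carbon

This account rests on a few compounds, and the source may have more. Where it says the series, first, only, none or still open, it means among the compounds named here.

Among the compounds with values here, compound 2 `CN1CCN(C(=S)SCc2ccc(C(=O)Nc3ccccc3N)cc2)CC1` is one of two compounds so far measured in a functional assay on HeLa cells (Homo sapiens) for antiproliferative activity, read by CCK-8 assay, with a stated time of 72 h, tested at 8 uM; on this read-out higher numbers stand for a stronger effect at the one concentration tested and lower numbers for a weaker effect. In this assay compound 2 gives 75.7%, and compound 1 `CC1CCN(C(=S)SCc2ccc(C(=O)Nc3ccccc3N)cc2)CC1` gives 72.5%. Within the data shown here, the single measured step, a number 3.2 percentage points higher from compound 1 to compound 2 (within the scatter), means the two numbers cannot be told apart, so compound 2 stands level with its only neighbour rather than clearly above it.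

Compound 3 `Nc1ccccc1NC(=O)c1ccc(CSC(=S)N2CCCC2)cc1` is not yet measured. It differs from compound 2 in one place: pyrrolidin-1-yl in place of 4-methylpiperazin-1-yl on a thiocarbonyl carbon. Among the measured compounds shown here, the only measured step that bears on this change is a number 3.2 percentage points higher from compound 1 to compound 2 (within the scatter), which replaced one six-membered saturated ring on the thiocarbonyl carbon by another and stayed within the scatter. On that basis an exchange of the ring at this position, now for a five-membered one, is expected to move the read-out little. The expected step is a number 3.7 percentage points lower from compound 2 to compound 3 (within the scatter), no change beyond the scatter. Compound 3 is therefore estimated at 72%, with a range from 55% to 85%.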

Compound 3, a percentage reported as inhibition, at one concentration (the size of the read-out at that concentration, not a potency): 77.8%
The estimate for compound 3 lay 5.8 percentage points below the measured number, within the range that was stated.
By their numbers in this assay, from the lowest: compounds 1, 2 and 3 (each within the scatter of the next).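

The five-membered ring fits the pattern of the six-membered pair. In this assay, pyrrolidin-1-yl gives a number 2.1 percentage points higher from compound 2 to compound 3 (within the scatter), and set against the other six-membered ring it gives a number 5.3 percentage points higher from compound 1 to compound 3 (within the scatter), so all three compounds stand level. Earlier, only an exchange between two six-membered rings could be read; now the ring on the thiocarbonyl carbon can also become smaller and lose the second ring nitrogen, the methyl group and the hydrogen-bond acceptor counted for 4-methylpiperazin-1-yl, with no difference that can be told from the scatter. No evidence is at hand that bears on this result.

Still open, going by these compounds, is whether the level read-out holds for groups of another kind on the thiocarbonyl carbon, such as an open-chain diethylamine, a morpholin-4-yl ring or a piperidine ring carrying a carboxylic acid. Since the read-out gives the size of the effect at one concentration and not a potency, it also leaves open whether compounds 1, 2 and 3 would separate across a range of concentrations.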